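This account rests on a few compounds, and the source may have more. Where it says the series, first, only, none or still open, it means among the compounds named here.

Measured so far in a functional assay on A549 cells (Homo sapiens) for cytotoxicity, read by MTT assay, with a stated time of 72 h; on this read-out lower numbers stand for stronger inhibition and higher numbers for weaker inhibition:
compound 1 `CN(C)CCn1cnnc1-c1cc(Oc2ccc(NC(=O)N/N=C/c3ccc(O)c(Br)c3)cc2F)ccn1` gives 1370 nM
compound 2 `CN(C)CCn1cnnc1-c1cc(Oc2ccc(NC(=O)N/N=C/c3ccc(F)cc3F)cc2F)ccn1` gives 1870 nM
compound 3 `CN(C)CCn1cnnc1-c1cc(Oc2ccc(NC(=O)N/N=C/c3c(O)ccc4ccccc34)cc2F)ccn1` gives 880 nM

Compound 3 carries the lowest number of the three in this assay. The step from compound 1 is a 1.6-fold lower number from compound 1 to compound 3 (0.19 log units; within the scatter); the step from compound 2 is a 2.1-fold lower number from compound 2 to compound 3 (0.33 log units; beyond the scatter). All three share one core and differ only in the aryl group on the carbon with a double bond to nitrogen.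

Compound 4 `CN(C)CCn1cnnc1-c1cc(Oc2ccc(NC(=O)N/N=C/c3ccc(O)c(F)c3)cc2F)ccn1` is not yet measured. Its change from compound 3 is 3-fluoro-4-hydroxyphenyl in place of 2-hydroxynaphthalen-1-yl on a carbon with a double bond to nitrogen. Among the compounds with values here, two measured steps bear on this. The step of a 1.6-fold lower number from compound 1 to compound 3 (0.19 log units; within the scatter) shows that exchanging 3-bromo-4-hydroxyphenyl for 2-hydroxynaphthalen-1-yl stays within the scatter, so the return to a 4-hydroxyphenyl bearing a halogen should at most undo that. The step of a 2.1-fold lower number from compound 2 to compound 3 (0.33 log units; beyond the scatter) marks the largest shift seen in the set. Within the data shown here, compound 4 differs from compound 1 only in fluorine where compound 1 has bromine; no measured pair tests that exchange. The expected step is therefore a 1.5-fold higher number from compound 3 to compound 4 (0.17 log units; within the scatter), within or at the edge of the scatter. Compound 4 is estimated at 1300 nM, with a range of 600 nM to 2800 nM.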

Compound 4, half-maximal inhibitory concentration: 13400 nM
Estimate against measurement, compound 4: 10-fold (1.01 log units) below; measured number outside the range, above it.
By their numbers in this assay, from the lowest: compounds 3, 1 and 2 (each within the scatter of the next, the first and the last beyond it); then compound 4.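

In this assay, the halogen on the aromatic carbon matters far more than the earlier aryl exchanges suggested: fluoro in place of bromo gives a 9.8-fold higher number from compound 1 to compound 4 (0.99 log units; beyond the scatter), so a 4-hydroxyphenyl bearing a halogen does not by itself keep the number low. Within the data shown here, the 3-fluoro-4-hydroxyphenyl group also stands apart from the other two aryl groups, with a 7.2-fold higher number from compound 2 to compound 4 (0.86 log units; beyond the scatter) and a 15-fold higher number from compound 3 to compound 4 (1.18 log units; beyond the scatter), while the earlier compounds spanned only a 2.1-fold lower number from compound 2 to compound 3 (0.33 log units; beyond the scatter). Nothing available here accounts for this jump.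

As far as these compounds go, whether the number tracks the identity of the halogen stays open; chloro or iodo on the same aromatic carbon, or plain hydrogen there, would place the fluoro and bromo results on a wider scale. A methoxy group in place of the hydroxy group would show whether the high number of compound 4 depends on that hydroxy group.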